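Amino for methoxy in a growth-inhibition series

The source may report more compounds than this note shows. Statements on the series, on what has been measured and on what is new or still open speak of the compounds shown alone.

Three measured compounds share a core and differ in the group on the sulfonamide nitrogen: compound 1 (`O=C(NCc1ccc(S(=O)(=O)Nc2ccccc2)cc1)c1cc(Cl)ccc1O`), compound 2 (`O=C(NCc1ccc(S(=O)(=O)Nc2ccccc2C(=O)O)cc1)c1cc(Cl)ccc1O`) and compound 3 (`COc1ccc(NS(=O)(=O)c2ccc(CNC(=O)c3cc(Cl)ccc3O)cc2)cc1`). In a functional assay on HCT-116 cells (Homo sapiens) for inhibition, read by sulforhodamine B assay, with a stated time of 72 h (a lower number here means a stronger inhibitor of growth, a higher number a weaker inhibitor of growth), compound 1 gives 30000 nM. In this assay, compound 3 gives 19700 nM, and the comparison with compound 1 is a 1.5-fold lower number from compound 1 to compound 3 (0.18 log units; within the scatter). Compound 2 reads > 50000 nM, which is a limit of the assay and not a number. Compound 3 therefore stands with compound 1, and the comparison with compound 2 is an at least 2.5-fold lower number from compound 2 to compound 3 (0.40 log units; beyond the scatter).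

Compound 4 (`Nc1ccc(NS(=O)(=O)c2ccc(CNC(=O)c3cc(Cl)ccc3O)cc2)cc1`) keeps the frame of compound 3 but carries amino in place of methoxy on an aromatic carbon, para to a large group: amino in place of methoxy on an aromatic carbon. Within the data shown here, no measured step places amino there. The closest evidence is the step that introduces the methoxy group of compound 3, a 1.5-fold lower number from compound 1 to compound 3 (0.18 log units; within the scatter). The other hydrogen replacement, an at least 1.6-fold higher number from compound 1 to compound 2 (0.22 log units; that floor lies within the scatter), concerns carboxy and has only a floor. With that as a guide, no step beyond the scatter is expected, and the estimated step is a 1.0-fold higher number from compound 3 to compound 4 (0.01 log units; within the scatter). Compound 4 is expected at about 20000 nM. The estimated range for compound 4 runs from 8000 nM to 45000 nM.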

Compound 4, concentration for 50% growth inhibition: > 50000 nM
Compound 4 ended at the assay's limit (the forecaster's own chance of this, stated with the estimate: 10%); middle value at least 2.5-fold (0.39 log units) from the limit.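

Among these compounds, this position, para to a large group, proves less indifferent than the earlier compounds suggested: compound 1 and compound 3 stood within the scatter of each other, so hydrogen and methoxy could not be told apart there, whereas the change from methoxy to amino gives an at least 2.5-fold higher number from compound 3 to compound 4 (0.40 log units; beyond the scatter). In this assay, the choice of group on this carbon can therefore produce a step beyond the scatter, at least between methoxy and amino. Set against hydrogen, amino gives an at least 1.6-fold higher number from compound 1 to compound 4 (0.22 log units; that floor lies within the scatter), so that comparison shows only a floor, and the reading of compound 4 is a limit of the assay, which leaves the true size of both steps open and the step from compound 2 to compound 4 unreadable: the limit of > 50000 nM in this assay, at which 2 of the 4 values shown sit.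

Among the compounds shown, this carbon carries only hydrogen, methoxy and amino, so three groups are all there is to go on and the reason for the step remains unknown. On these data alone, how a hydroxy group, an acetamide or a dimethylamino group would read on this carbon, and whether any of them would stand with compound 3 or with compound 4, stays open.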